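From dimethylamino to methylamino on compound 1

This account rests on a few compounds, and the source may have more. Where it says the series, first, only, none or still open, it means among the compounds named here.

In an ADME assay on microsomes from liver (Mus musculus) for metabolic stability, read by HPLC, with a stated time of 4 h (a higher number here means that the compound lasts longer, a lower number that the compound disappears faster), compound 1 (`CN(C)c1ccc2cc(-c3cn(C)c4ccccc34)c(N)nc2c1`) gives 0.26 h and stands second highest of the three measured numbers. In this assay compound 3 (`Nc1nc2cc(N3CCCCC3)ccc2cc1-c1cc(Cl)cc(Cl)c1`) gives 0.1 h and lies below compound 1 by more than the scatter. Compound 2 (`CN(C)c1ccc2cc(-c3nc4cc(C(C)(C)C)ccc4o3)c(N)nc2c1`) gives 1.3 h and lies above compound 1, again beyond the scatter.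

Compound 4 (`CNc1ccc2cc(-c3cn(C)c4ccccc34)c(N)nc2c1`) has not yet been measured. It differs from compound 1 by a single change, hydrogen in place of methyl on a nitrogen on an aromatic ring so that dimethylamino becomes methylamino. No two of the measured compounds differ in only one place, and the data therefore give no direct measure of what this change does in this assay. The expectation rests on compound 1 at 0.26 h as the closest measured neighbour, and no direction is favoured. The estimated step of a 1.2-fold higher number from compound 1 to compound 4 (0.06 log units; within the scatter) is expected to stay within the scatter. For compound 4 the expected half-life is 0.3 h with an estimated range from 0.13 h to 0.7 h in repeated measurements.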

Compound 4, half-life: 1.3 h
Compound 4: middle estimate off by 4.3-fold (0.64 log units), on the low side; measured number outside the range, above it.
By their numbers in this assay, from the lowest: compound 3; then compound 1; then compounds 2 and 4 (each within the scatter of the next).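

In this assay, among the compounds shown here, taking one methyl off the dimethylamino group to leave methylamino gives a 5.0-fold higher number from compound 1 to compound 4 (0.70 log units; beyond the scatter), and this is the first single change in the set whose size can be read directly, since the earlier compounds all differed in more than one place. It shows that this nitrogen on an aromatic ring is not a silent spot for the half-life: with the rest of compound 1 kept, the loss of one carbon, with no ring and no net charge involved, moves the number beyond the scatter. Nothing available here bears on why the half-life responds to this change, so the reason stays unknown.

The compounds shown leave open whether the trend continues along this nitrogen, for instance with the second methyl also replaced by hydrogen to give a plain amino group, or with an ethyl group in place of the methyl of methylamino. They also leave open whether the same change would have a step of similar size on compound 2, which carries the same dimethylamino group beside a different aryl partner on the shared core.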